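Furan-3-yl to thiophen-2-yl on the shared core

This account rests on a few compounds, and the source may have more. Where it says the series, first, only, none or still open, it means among the compounds named here.

Compound 1 `Nc1nc(N)c2c(-c3cccs3)cn([C@@H]3O[C@H](CO)[C@@H](O)[C@H]3O)c2n1`: > 20000 nM
Compound 2 `COc1nc(N)nc2c1c(-c1ccco1)cn2[C@@H]1O[C@H](CO)[C@@H](O)[C@H]1O`: > 20000 nM
Compound 3 `COc1nc(N)nc2c1c(-c1ccoc1)cn2[C@@H]1O[C@H](CO)[C@@H](O)[C@H]1O`: > 20000 nM

All three entries come from a functional assay on HL-60 cells (Homo sapiens) for antiproliferative activity, read by XTT assay, with a stated time of 72 h (on this read-out lower numbers stand for stronger inhibition and higher numbers for weaker inhibition), and all three are limits, not numbers. Going by the values given here, the series so far sits at the limit of > 20000 nM in this assay, at which 3 of the 3 values shown sit. Compound 3 therefore has no numerical rank, and compound 3 stands at the limit of > 20000 nM.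

Compound 4 `COc1nc(N)nc2c1c(-c1cccs1)cn2[C@@H]1O[C@H](CO)[C@@H](O)[C@H]1O` carries thiophen-2-yl in place of furan-3-yl on an aromatic carbon of the five-membered aromatic ring with 1 nitrogen: thiophen-2-yl in place of furan-3-yl on an aromatic carbon.

Among the compounds with values here, the one measured step that bears directly on this position is the exchange of furan-2-yl for furan-3-yl, a step that the two limits leave unreadable from compound 2 to compound 3. Both ends of that step are limits, so it offers no size to carry over. Compound 1 also carries thiophen-2-yl, on a different core, and compound 1 gives > 20000 nM, again a limit.

With compound 3 at > 20000 nM, no readable step is expected in this assay, and a reported limit is the likeliest result; any readable number would lie on the side of stronger inhibition. The expected change is a step that the limit leaves unreadable from compound 3 to compound 4. For compound 4 the estimated value is 25000 nM, with an expected range from 8000 nM to 60000 nM.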

Compound 4, half-maximal inhibitory concentration: > 20000 nM
Compound 4 was reported as a limit; the forecaster's own chance of this, stated with the estimate: 85%; the middle value lies beyond the limit too.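

Going by these compounds alone, no step to compound 4 can be read from compound 1, compound 2 or compound 3, since all four entries in this assay are limits and not numbers: the limit of > 20000 nM in this assay, at which 4 of the 4 values shown sit.

The compounds shown leave open whether thiophen-2-yl, furan-2-yl and furan-3-yl differ from one another in antiproliferative activity, and whether methoxy and amino differ on the shared core.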